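A tosylaminomethyl group replaces the tolyl on the triazole

The source may hold more compounds than are shown below. What is called first, only, known or untested is meant among the compounds shown, and "the series" means these compounds.

The series rests on a shared core that carries a tert-butyl group in compound 1 `CC(C)(C)c1cn(C[C@H](O)[C@H]2OC(=O)C(OCc3ccccc3)=C2OCc2ccccc2)nn1` and a 4-methylphenyl group in compound 2 `Cc1ccc(-c2cn(C[C@H](O)[C@H]3OC(=O)C(OCc4ccccc4)=C3OCc3ccccc3)nn2)cc1`. In a functional assay on SW-620 cells (Homo sapiens) for antiproliferative activity, read by MTT assay, with a stated time of 72 h (a higher number here means a weaker inhibitor, a lower number a stronger inhibitor), compound 1 gives 35800 nM. Compound 2 reaches only the limit of the assay, > 100000 nM, so its position is known solely as a limit (the limit of > 100000 nM in this assay, at which 1 of the 2 values shown sits). Among the measured compounds shown here, the one step that could be counted, an at least 2.7-fold higher number from compound 1 to compound 2 (0.44 log units; beyond the scatter), is therefore itself an open-ended weakening. Compound 3 `Cc1ccc(S(=O)(=O)NCc2cn(C[C@H](O)[C@H]3OC(=O)C(OCc4ccccc4)=C3OCc3ccccc3)nn2)cc1` carries (((4-methylphenyl)sulfonyl)amino)methyl in place of 4-methylphenyl on an aromatic carbon. For the measured compounds named here, no measured step covers this change; the only counted step concerns the leaving group and gives no direction for the entering one. The number for compound 3 is expected to stay near the limit, with an at least 1.1-fold lower number from compound 2 to compound 3 (0.04 log units; that floor lies within the scatter) meaning essentially no change beyond the scatter. For compound 3 the estimate is 90000 nM, within 25000 nM to 300000 nM.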

Compound 3, half-maximal inhibitory concentration: 45800 nM
Compound 3: middle estimate off by 2.0-fold (0.29 log units), on the high side; the range from low to high includes it.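

At this aromatic carbon, the (((4-methylphenyl)sulfonyl)amino)methyl group gives a measurable number in this assay, with an at least 2.1-fold lower number from compound 2 to compound 3 (0.33 log units; beyond the scatter), so a 4-methylphenyl unit in the substituent does not by itself hold a compound at the limit. Compound 2 remains only a limit of the assay, > 100000 nM, which leaves that step open-ended: the limit of > 100000 nM in this assay, at which 1 of the 3 values shown sits. Set against the tert-butyl group, the same entering group gives a 1.3-fold higher number from compound 1 to compound 3 (0.11 log units; within the scatter), so this position does not separate these two groups in this assay.

The compounds shown leave open whether the sulfonyl group, the amide-type hydrogen or the methylene link carries the step from the directly attached 4-methylphenyl group. They also leave open how a plain aminomethyl group or a carboxylic acid would read on this carbon.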